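A few compounds are considered here, and "the series" means these few. Any claim that something is new, unique, unknown or untested is made for them only; others in the source may bear on it.

In an ADME assay on HEK293 cells (Homo sapiens) for cytotoxicity, read by resazurin assay, with a stated time of 48 h (on this read-out lower numbers stand for higher toxicity in this test and higher numbers for lower toxicity in this test), three compounds that share a core and differ only in the group on a sulfonyl sulfur have been measured. Compound 1 `COc1cccc(S(=O)(=O)Nc2ccc3oc(-c4ccccc4)nc3c2)c1` gives 63000 nM, and compound 2 `O=S(=O)(Nc1ccc2oc(-c3ccccc3)nc2c1)c1cccs1` gives 97000 nM. Compound 3 `O=S(=O)(Nc1ccc2oc(-c3ccccc3)nc2c1)c1ccc(O)cc1` gives > 100000 nM, which is a limit of the assay and not a number.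

Compound 4 `Cc1cccc(S(=O)(=O)Nc2ccc3oc(-c4ccccc4)nc3c2)c1` has 3-methylphenyl in place of 4-hydroxyphenyl on a sulfonyl sulfur. The measured steps all change this same group. The first, a 1.5-fold higher number from compound 1 to compound 2 (0.19 log units; within the scatter), lies within the scatter, and so do the floors of the other two, an at least 1.5-fold higher number from compound 1 to compound 3 (0.20 log units; that floor lies within the scatter) and an at least 1.0-fold higher number from compound 2 to compound 3 (0.01 log units; that floor lies within the scatter). No change at this place has yet gone beyond the scatter, so none is expected here in this assay. The closest named group is the 3-methoxyphenyl of compound 1, at 63000 nM, and the estimate leans towards that value. The expected size is an at least 1.4-fold lower number from compound 3 to compound 4 (0.15 log units; that floor lies within the scatter), which would stay within the scatter. For compound 4, the estimated value is 70000 nM, with an expected range from 35000 nM to 100000 nM.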

Compound 4, half-maximal cytotoxic concentration: 69000 nM
Beside the measured number, compound 4's estimate is 1.0-fold (0.01 log units) above it; the measured number falls inside the stated range.
By their numbers in this assay, from the lowest: compounds 1, 4 and 2 (each within the scatter of the next). At a limit, above all of these: compound 3.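

The 3-methylphenyl group of compound 4 has 0 hydrogen-bond donors and 0 hydrogen-bond acceptors, where the 4-hydroxyphenyl group it replaces has 1 of each, yet in this assay the floor of this change stays within the scatter: an at least 1.4-fold lower number from compound 3 to compound 4 (0.16 log units; that floor lies within the scatter). Compound 3 has a limit of the assay and not a number: the limit of > 100000 nM in this assay, at which 1 of the 4 values shown sits. The swap of a single group on the ring, methyl in place of methoxy, also stays within the scatter, as does the exchange of the thiophen-2-yl ring for a substituted phenyl ring: a 1.1-fold higher number from compound 1 to compound 4 (0.04 log units; within the scatter) and a 1.4-fold lower number from compound 2 to compound 4 (0.15 log units; within the scatter).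

Going by these compounds, whether an amine or a carboxylic acid on this ring would move the number beyond the scatter remains open. So does the effect of a longer chain in place of the ring, and of any change elsewhere on the shared core.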